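This account rests on a few compounds, and the source may have more. Where it says the series, first, only, none or still open, it means among the compounds named here.

Measured so far:
compound 1, `Cc1nc(-c2ccc(C(F)(F)F)cc2)sc1CNc1ccc(CCC(=O)O)cc1`, 67.6 nM in a functional assay on CHO cells for agonist activity at Free fatty acid receptor 1 (Homo sapiens); on this read-out lower numbers stand for an effect already at smaller amounts and higher numbers for an effect only at larger amounts of compound
compound 2, `O=C(O)CSc1ccc(NCc2cccc(Oc3ccccc3)c2)cc1`, 324 nM

Compound 2 stands at the highest of the two numbers measured; the nearest is compound 1, whose value lies beyond the scatter of repeated runs. Both measured compounds carry a free carboxylic acid at the end of the chain on the aniline-type ring.

Compound 3, `CN(C)C(=O)CCc1ccc(NCc2cccc(Oc3ccccc3)c2)cc1`, has not been measured. It differs from compound 2 in one place: 2-(dimethylcarbamoyl)ethyl in place of (carboxymethyl)sulfanyl on an aromatic carbon. With this change the carboxylic acid that both measured compounds share is gone, and the single hydrogen-bond donor of the group that leaves is not replaced. Among the measured compounds shown here, no measured pair shows a step of this kind, so the size of the step can only be guessed from the fact that the acid is present in every compound with a number so far.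

The step from compound 2 to compound 3 is expected to be large and toward higher numbers, a 15-fold higher number from compound 2 to compound 3 (1.19 log units; beyond the scatter). For compound 3 the estimate in this assay is 5000 nM, with a range from 1000 nM to 30000 nM, and a fair chance that only a limit is reported.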

Compound 3, half-maximal effective concentration: 174 nM
Estimate against measurement, compound 3: 29-fold (1.46 log units) above; measured number below the stated range.
By their numbers in this assay, from the lowest: compound 1; then compounds 3 and 2 (each within the scatter of the next).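

In this assay the exchange of (carboxymethyl)sulfanyl for 2-(dimethylcarbamoyl)ethyl on an aromatic carbon, para to a large group, gives a 1.9-fold lower number from compound 2 to compound 3 (0.27 log units; within the scatter) and so leaves the read-out unchanged within the usual scatter. For this pair, the free carboxylic acid and the single hydrogen-bond donor of the leaving group can therefore be lost without a change beyond the scatter, something compounds 1 and 2 could not show, as both carry the acid. No measurement in hand accounts for this result.

The change removes the sulfur, the acid and the hydrogen-bond donor in a single step while also adding a nitrogen and two further heavy atoms, so the compounds shown leave open which of these differences matters, if any does, and whether the two opposing effects might cancel. Also open, going by these compounds, is how this position responds to a primary amide, a tetrazole or a basic amine on the same chain, and whether the dimethylamide would be accepted equally on the core of compound 1.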